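Isopropyl Replaces Dichlorophenyl on the Ring Nitrogen

The source may report more compounds than this note shows. Statements on the series, on what has been measured and on what is new or still open speak of the compounds shown alone.

Measured compounds:
compound 1, `Cc1ccc(-c2nn(-c3ccc(F)cc3)cc2C(=O)Nc2ccc(C)c(S(=O)(=O)N3CCOCC3)c2)cc1`, 2490 nM
compound 2, `Cc1ccc(-c2nn(-c3ccc(Cl)cc3Cl)cc2C(=O)Nc2ccc(C)c(S(=O)(=O)N3CCOCC3)c2)cc1`, 1240 nM

In an assay on HEK-293T cells for inhibition of Bile acid receptor (Homo sapiens), read by a beta-lactamase reporter, with a stated time of 16 h (a higher number here means a weaker inhibitor, a lower number a stronger inhibitor), compound 2 holds the lowest of the two numbers, with compound 1 nearest at a step of a 2.0-fold lower number from compound 1 to compound 2 (0.30 log units; within the scatter). Compound 3, `Cc1ccc(-c2nn(C(C)C)cc2C(=O)Nc2ccc(C)c(S(=O)(=O)N3CCOCC3)c2)cc1`, differs from compound 2 by isopropyl in place of 2,4-dichlorophenyl on an aromatic nitrogen. Within the data shown here, the only measured step swaps one aryl for another and stays within the scatter, so nothing here tells how removing the aryl altogether acts. A weakening step is expected, a 4.0-fold higher number from compound 2 to compound 3 (0.61 log units; beyond the scatter), with wide uncertainty. Compound 3 is estimated at 5000 nM, ranging from 1500 nM to 20000 nM.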

Compound 3, half-maximal inhibitory concentration: 1690 nM
Estimate against measurement, compound 3: 3.0-fold (0.47 log units) above; low and high end bracket the measured number.
By their numbers in this assay, from the lowest: compounds 2, 3 and 1 (each within the scatter of the next).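

In this assay, the aryl ring on this nitrogen turns out not to be needed to keep the number in this range: a 1.4-fold higher number from compound 2 to compound 3 (0.13 log units; within the scatter), and a 1.5-fold lower number from compound 1 to compound 3 (0.17 log units; within the scatter). Isopropyl, with no ring and 3 heavy atoms, therefore reads alike with both aryl groups at this position, which the aryl-for-aryl step could not show. Nothing measured here explains why these groups read alike.

On these data alone, it remains open whether a longer chain on this nitrogen would also read alike. The same holds for a chain ending in an amine or a carboxylic acid.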